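Coumarin amide series: ester on the amine side chain

A few compounds are considered here, and "the series" means these few. Any claim that something is new, unique, unknown or untested is made for them only; others in the source may bear on it.

Two compounds have numbers in a functional assay on SK-BR-3 cells (Homo sapiens) for antiproliferative activity; on this read-out higher numbers stand for weaker inhibition and lower numbers for stronger inhibition. Compound 1 `CC(=O)Oc1ccc(C(=O)Nc2cc3ccc(OCC4CCCNC4)c(C)c3oc2=O)cc1CC=C(C)C` gives 620 nM in this assay. Compound 2 `CCNCCCOc1ccc2cc(NC(=O)c3ccc(O)c(CC=C(C)C)c3)c(=O)oc2c1C` gives 720 nM in this assay. Among the compounds with values here, these two numbers sit within the scatter of each other, so compound 2 is not separated from compound 1 on this read-out, and no step between measured compounds is available as a guide.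

Compound 3 `COC(=O)CNCCCOc1ccc2cc(NC(=O)c3ccc(O)c(CC=C(C)C)c3)c(=O)oc2c1C` has not been measured. Its structure differs from that of compound 2 in one place: methoxycarbonyl in place of methyl on a saturated chain carbon bound to an amine nitrogen. The chain on the amine nitrogen thus reads (methoxycarbonyl)methyl instead of ethyl, with the rest of the molecule unchanged, including the hydroxy group and the prenyl-type chain on the amide side and the methyl on the shared core.

Within the data shown here, with no comparable step in the data, the expectation rests on the size of the change alone. The step of a 1.3-fold higher number from compound 2 to compound 3 (0.12 log units; within the scatter) is expected to stay within the scatter, with a slight lean toward a higher number. Compound 3 is accordingly estimated at 950 nM in this assay, with a range from 400 nM to 2500 nM.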

Compound 3, half-maximal inhibitory concentration: 1060 nM
For compound 3 the middle estimate is 1.1-fold (0.05 log units) below the measured one, within the range that was stated.
By their numbers in this assay, from the lowest: compounds 1, 2 and 3 (each within the scatter of the next).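

In this assay, within the data shown here, the replacement of ethyl by (methoxycarbonyl)methyl on the amine gives a 1.5-fold higher number from compound 2 to compound 3 (0.17 log units; within the scatter) and is the first single-place comparison, so the amine side chain now has a direct reading. The entering methoxycarbonyl brings four heavy atoms in place of one, along with two hydrogen-bond acceptors, yet compound 3 is not separated from compound 2 on this read-out, which shows that this position tolerates at least this one substantial change in the group carried on a saturated chain carbon bound to an amine nitrogen. No measurement of any other kind accompanies this pair, so the result stands without an explanation.

A single ester does not settle whether the position tolerates change generally, and a carboxylic acid in place of the methoxycarbonyl, a primary amide or a longer chain carrying the ester would each test that further. On these data alone, compound 1 differs from both in more than one place, so the same question remains open for its piperidine-free reading of the amine side chain and its acetate on the amide side.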